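This account rests on a few compounds, and the source may have more. Where it says the series, first, only, none or still open, it means among the compounds named here.

Of the compounds shown here, three in this set have been measured. Compound 1 `CN(C)CCCN1CCN(CC(=O)Nc2ccc(-c3nc4cc(F)ccc4o3)cc2)CC1` and compound 2 `Cc1ccc2oc(-c3ccc(NC(=O)CN4CCN(CCCN(C)C)CC4)cc3)nc2c1` share a core that carries the same amide-linked chain, while compound 3 `Cc1ccc2oc(-c3ccc(NC(=O)CCl)cc3)nc2c1` lacks that chain. In a functional assay on HT-29 cells (Homo sapiens) for cytotoxicity, read by MTT assay, with a stated time of 24 h (on this read-out lower numbers stand for stronger inhibition and higher numbers for weaker inhibition), compound 1 gives 2590 nM, and compound 2 gives 3890 nM. The change between them, (fluoro in place of methyl on an aromatic carbon), is a 1.5-fold lower number from compound 2 to compound 1 (0.18 log units; within the scatter). Compound 3 gives 15200 nM in this assay, the highest number of the three, and the difference between the core of compound 3 and that of compound 2 is not broken down here.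

Compound 4 `O=C(CCl)Nc1ccc(-c2nc3cc(F)ccc3o2)cc1` has not yet been measured. It differs from compound 3 by fluoro in place of methyl on an aromatic carbon, the same change that turns compound 2 into compound 1. Because that earlier step was a 1.5-fold lower number from compound 2 to compound 1 (0.18 log units; within the scatter), a step of about that size is expected here as well, with the usual scatter around it. Compound 4 in this assay is therefore expected near 11000 nM, between 4500 nM and 28000 nM. The expected step is a 1.4-fold lower number from compound 3 to compound 4 (0.14 log units; within the scatter).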

Compound 4, half-maximal inhibitory concentration: 6930 nM
Beside the measured number, compound 4's estimate is 1.6-fold (0.20 log units) above it, within the range that was stated.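

In this assay, fluoro in place of methyl on an aromatic carbon gives a 2.2-fold lower number from compound 3 to compound 4 (0.34 log units; beyond the scatter), and this can be set beside the same change on the other core: the same change on two cores in this assay, a 1.5-fold lower number (0.18 log units; within the scatter) from compound 2 to compound 1 and a 2.2-fold lower number (0.34 log units; beyond the scatter) from compound 3 to compound 4, 1.5-fold (0.16 log units) apart, within the scatter of two such steps. Among these compounds, the change therefore carries across these two cores without a step size that can be told apart, and both steps run towards lower numbers, although only the one from compound 3 to compound 4 lies beyond the scatter by itself. This rests on two pairs in a single assay, so it does not show that the step would hold on further cores, and it says nothing about why the numbers move.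

The compounds shown leave open how other groups in the same place would compare with methyl and fluoro, such as chloro, methoxy, trifluoromethyl or plain hydrogen. They also leave open whether the step stays the same when the amide carries a different amine, such as morpholine, or a longer chain.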